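The source may hold more compounds than are shown below. What is called first, only, known or untested is meant among the compounds shown, and "the series" means these compounds.

Measured in a functional assay on LNCaP cells (Homo sapiens) for antiproliferative activity, read by propidium iodide staining, with a stated time of 96 h; a higher number here means a weaker inhibitor, a lower number a stronger inhibitor:
Compound 1 `CC(O)(CSc1cccc(S(F)(F)(F)(F)F)c1)C(=O)Nc1ccc(S(F)(F)(F)(F)F)cc1`: 25000 nM
Compound 2 `CC(O)(COc1cccc(S(F)(F)(F)(F)F)c1)C(=O)Nc1ccc(C#N)c(C(F)(F)F)c1`: 9800 nM
Compound 3 `CC(O)(COc1ccc(S(F)(F)(F)(F)F)cc1)C(=O)Nc1ccc(S(F)(F)(F)(F)F)cc1`: 9800 nM

Compound 2 is level with compound 3 at 9800 nM, and together they hold the lowest number of the three. Compound 1 stands higher at 25000 nM, a gap beyond the scatter.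

Compound 4 `CC(O)(COc1ccc(OC(F)(F)F)cc1)C(=O)Nc1ccc(S(F)(F)(F)(F)F)cc1` departs from compound 3 in one place: a group of 5 heavy atoms (1 carbon, 1 oxygen, 3 fluorine; no ring) in place of a group of 6 heavy atoms (5 fluorine, 1 sulfur; no ring), on an aromatic carbon. Trifluoromethoxy enters on an aromatic carbon, para to a large group.

Among the compounds with values here, no measured pair differs in one place only, so the data offer no direct precedent for this change. With that gap in mind, no step beyond the scatter is expected in this assay, and the reference point remains compound 3 at 9800 nM. The estimated change is a 1.0-fold higher number from compound 3 to compound 4 (0.01 log units; within the scatter). The range stays wide, and its upper end reaches the level of compound 1 at 25000 nM. For compound 4 the estimate is 10000 nM, with an expected range of 4000 nM to 25000 nM.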

Compound 4, half-maximal inhibitory concentration: 18600 nM
The estimate for compound 4 lay 1.9-fold (0.27 log units) below the measured number; measured number inside the range.
By their numbers in this assay, from the lowest: compounds 2, 3, 4 and 1 (each within the scatter of the next, the first and the last beyond it).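

Within the data shown here, this is the first single-place pair: in this assay, trifluoromethoxy in place of the group of 5 fluorine and 1 sulfur, on an aromatic carbon para to a large group, gives a 1.9-fold higher number from compound 3 to compound 4 (0.28 log units; within the scatter). This position therefore accepts either group without a step beyond the usual scatter, although the entering group has 1 hydrogen-bond acceptor and the leaving group has 0. No measured property or other supporting data accounts for the size of this step.

The compounds shown leave open how an amine or a carboxylic acid would read at this position. As far as these compounds go, the same exchange elsewhere on the shared core, or on the core of compound 1, also remains open, since this single pair speaks only for the position and background of compound 3.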